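Benzyloxycarbonyl variant of compound 1 and its permeability

The source may report more compounds than this note shows. Statements on the series, on what has been measured and on what is new or still open speak of the compounds shown alone.

Compound 1 `Cn1cncc1CN1CC(N(CC2CCN(C(=O)c3ccc(Cl)cc3)CC2)S(=O)(=O)c2ccccn2)Cc2cc(C#N)ccc21` is the reference. In an ADME assay on Caco-2 cells (Homo sapiens) for permeability, in the apical to basolateral direction (on this read-out higher numbers stand for higher permeability and lower numbers for lower permeability), compound 1 gives 0.5 10^-6 cm/s, the highest of the three numbers shown. Compound 2 `Cn1cncc1CN1CC(N(CC2CCN(S(C)(=O)=O)CC2)S(=O)(=O)c2ccccn2)Cc2cc(C#N)ccc21` gives 0.1 10^-6 cm/s and compound 3 `Cn1cnc(S(=O)(=O)N2CCC(CN(C3Cc4cc(C#N)ccc4N(Cc4cncn4C)C3)S(=O)(=O)c3ccccn3)CC2)c1` gives 0.1 10^-6 cm/s; the steps are a 5.0-fold lower number from compound 1 to compound 2 (0.70 log units; beyond the scatter) and a 5.0-fold lower number from compound 1 to compound 3 (0.70 log units; beyond the scatter), while no change at the digits printed from compound 2 to compound 3 (within the scatter). Compound 4 `Cn1cncc1CN1CC(N(CC2CCN(C(=O)OCc3ccccc3)CC2)S(=O)(=O)c2ccccn2)Cc2cc(C#N)ccc21` differs from compound 1 by benzyloxy in place of 4-chlorophenyl on a carbonyl carbon. Neither measured step bears directly on this change: both replaced the (4-chlorophenyl)carbonyl with a sulfonyl group, whereas compound 4 keeps a carbonyl carbon on the amide-type nitrogen in a ring and keeps one six-membered aromatic ring of carbon only. The step of a 1.3-fold lower number from compound 1 to compound 4 (0.10 log units; within the scatter) is therefore expected to lie within the scatter. The estimate for compound 4 is 0.4 10^-6 cm/s, ranging from 0.15 10^-6 cm/s to 1 10^-6 cm/s.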

Compound 4, apparent permeability: 1 10^-6 cm/s
Compound 4: the middle estimate sits 2.5-fold (0.40 log units) below what was measured; low and high end bracket the measured number.
By their numbers in this assay, from the lowest: compounds 2 and 3 (each within the scatter of the next); then compounds 1 and 4 (each within the scatter of the next).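

In this assay the exchange of 4-chlorophenyl for benzyloxy on the carbonyl carbon gives a 2.0-fold higher number from compound 1 to compound 4 (0.30 log units; within the scatter) and so does not separate the two carbonyl compounds. Against the sulfonyl compounds, benzyloxycarbonyl on the ring nitrogen gives a 10-fold higher number from compound 2 to compound 4 (1.00 log units; beyond the scatter) and a 10-fold higher number from compound 3 to compound 4 (1.00 log units; beyond the scatter) in the same read-out, which places compound 4 with compound 1 in the upper pair, with no exception among the compounds shown. No available evidence accounts for these steps. On these data alone, it remains open whether the benzyloxy oxygen matters, which a 2-phenylethyl group on the same carbonyl carbon would test. As far as these compounds go, the role of the chlorine is also open, and a plain phenyl there would address it.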